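The source may hold more compounds than are shown below. What is called first, only, known or untested is meant among the compounds shown, and "the series" means these compounds.

Compound 1 `Nc1scc(CN2CCN(c3ccccc3C(F)(F)F)CC2)c1C(=O)c1ccc(Cl)cc1` shares its core with compound 2 `Nc1scc(CN2CCN(c3ccc(C(F)(F)F)cc3)CC2)c1C(=O)c1cccc(C(F)(F)F)c1` and compound 3 `Nc1scc(CN2CCN(c3c(F)cccc3F)CC2)c1C(=O)c1cccc(C(F)(F)F)c1`. In an assay on CHO cells for displacement of a labelled ligand from adenosine receptor A3 (Homo sapiens), read by scintillation counting, with a stated time of 120 min, tested at 10 uM (a higher number here means more inhibition at the concentration tested (going by the name of the read-out), a lower number less inhibition), compound 1 gives 0%, compound 2 gives 0% and compound 3 gives 0%. Compound 1 thus stands level with both companions, within the scatter. Going by the values given here, the one measured step at the same place, no change at the digits printed from compound 2 to compound 3 (within the scatter), showed no movement. Compound 4 `Nc1scc(CN2CCN(c3cccc4ccccc34)CC2)c1C(=O)c1ccc(Cl)cc1` differs from compound 1 by naphthalen-1-yl in place of 2-(trifluoromethyl)phenyl on an amine nitrogen in a ring. Since the comparable exchange on an amine nitrogen in a ring, recorded as no change at the digits printed from compound 2 to compound 3 (within the scatter), was flat, the step from compound 1 to compound 4 is expected to stay within the scatter, and the expected step of a number 2 percentage points higher from compound 1 to compound 4 (within the scatter) is essentially nil. Compound 4 is therefore estimated at 2% in this assay, with a range from -8% to 15%.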

Compound 4, a percentage reported as inhibition, at one concentration (the size of the read-out at that concentration, not a potency): 0%
The estimate for compound 4 lay 2 percentage points above the measured number, within the range that was stated.
By their numbers in this assay, from the lowest: compounds 1, 2, 3 and 4 (each within the scatter of the next).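

In this assay, placing naphthalen-1-yl on the amine nitrogen in a ring, where compound 1 carries 2-(trifluoromethyl)phenyl, gave no change at the digits printed from compound 1 to compound 4 (within the scatter). At this position, then, a second six-membered aromatic ring of carbon only, with the three fluorines gone, left the read-out unmoved, extending the flat result to a change of ring count. No measurement bears on why the read-out stayed flat.

As far as these compounds go, whether an amine or a carboxylic acid on the aromatic ring at this position would move the read-out remains open.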